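The compounds below may be only part of what the source reports. "The series", "measured", "known", "first", "only" and "open" are said of these compounds alone.

Measured in an assay on isolated protein for inhibition of G protein-coupled receptor kinase 6 (Homo sapiens), read by scintillation counting, radiometric assay and 33P incorporation, with a stated time of 80 min, in the presence of a further agent that is not named here (on this read-out higher numbers stand for weaker inhibition and lower numbers for stronger inhibition), so far:

compound 1, `CCc1cc(Nc2nc(N[C@@H](C)c3cccc(F)c3)nc3ccccc23)n[nH]1`, 340 nM
compound 2, `CCc1cc(Nc2nc(N[C@@H](C)c3ccc(F)cc3)nc3ccccc23)n[nH]1`, 120 nM
compound 3, `CCc1cc(Nc2nc(NCc3ccc(F)cc3)nc3ccccc23)n[nH]1`, 250 nM

Within these three, compound 3 gives the second highest number; one of its neighbours lies within the scatter of it (a 1.4-fold lower number from compound 1 to compound 3 (0.13 log units; within the scatter)) and the other beyond it (a 2.1-fold higher number from compound 2 to compound 3 (0.32 log units; beyond the scatter)).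

Compound 4, `CCc1cc(Nc2nc(NCc3ccc(Cl)cc3OC)nc3ccccc23)n[nH]1`, has not yet been measured. It differs from compound 3 in one place: 4-chloro-2-methoxyphenyl in place of 4-fluorophenyl on a saturated chain carbon bound to a nitrogen on an aromatic ring.

Among the compounds with values here, two measured steps bear on this. Moving the fluorine around the aryl ring gave a 2.8-fold lower number from compound 1 to compound 2 (0.45 log units; beyond the scatter), so the substitution pattern of this ring does register, but only modestly. Removing the methyl from the chain carbon gave a 2.1-fold higher number from compound 2 to compound 3 (0.32 log units; beyond the scatter), also modest. Within the data shown here, no measured pair exchanges the fluorine for a chlorine or adds a methoxy, so the effect of this change is not anchored by any direct comparison. On this basis a step in this assay of about the size seen between compound 1 and compound 2 is the most that is expected, in either direction, and a step within the scatter is as likely as one beyond it.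

Compound 4 is therefore expected to give 280 nM, with a range of 110 nM to 750 nM, which amounts to an expected 1.1-fold higher number from compound 3 to compound 4 (0.05 log units; within the scatter).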

Compound 4, half-maximal inhibitory concentration: 40 nM
Compound 4: the middle estimate sits 7.0-fold (0.85 log units) above what was measured; measured number below the stated range.
By their numbers in this assay, from the lowest: compound 4; then compound 2; then compounds 3 and 1 (each within the scatter of the next).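

In this assay, within the data shown here, the aryl group on a saturated chain carbon bound to a nitrogen on an aromatic ring allows a larger change than the earlier compounds showed: 4-chloro-2-methoxyphenyl in place of 4-fluorophenyl gives a 6.3-fold lower number from compound 3 to compound 4 (0.80 log units; beyond the scatter) and exceeds both a 2.8-fold lower number from compound 1 to compound 2 (0.45 log units; beyond the scatter) and a 2.1-fold higher number from compound 2 to compound 3 (0.32 log units; beyond the scatter). This step occurs without the methyl on the chain carbon, since both of its compounds lack that group. Nothing available explains the size of this step.

On these data alone, the change brings in the chlorine and the methoxy together, so the share of each remains open. Also open, as far as these compounds go, are whether restoring the methyl on the chain carbon would add to this step and how an amine or a carboxylic acid on the aryl ring would read out.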